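Hydroxycyclohexyl replacing carbamoylmethyl on the sulfur

The source may report more compounds than this note shows. Statements on the series, on what has been measured and on what is new or still open speak of the compounds shown alone.

Measured so far:
- compound 1, `CC(C)c1n[nH]c2c(NCc3ccc(-c4ccccn4)cc3)nc(SCC(O)C(F)(F)F)nc12`: 690 nM
- compound 2, `CSc1nc(NCc2ccc(-c3ccccn3)cc2)c2[nH]nc(C(C)C)c2n1`: 783 nM
- compound 3, `CC(C)c1n[nH]c2c(NCc3ccc(-c4ccccn4)cc3)nc(SCC(N)=O)nc12`: 192 nM

In a functional assay on HT cells (Homo sapiens) for antiproliferative activity, read by fluorescence, with a stated time of 72 h (a higher number here means a weaker inhibitor of growth, a lower number a stronger inhibitor of growth), compound 3 gives the lowest of the three numbers, with compound 1 and compound 2 both beyond the scatter above it. Compound 4, `CC(C)c1n[nH]c2c(NCc3ccc(-c4ccccn4)cc3)nc(SC3CCCCC3O)nc12`, differs from compound 3 by 2-hydroxycyclohexyl in place of carbamoylmethyl on a sulfur. Going by the values given here, two steps bear on this: a 3.6-fold lower number from compound 1 to compound 3 (0.56 log units; beyond the scatter) and a 4.1-fold lower number from compound 2 to compound 3 (0.61 log units; beyond the scatter), both modest. Both show the carbamoylmethyl chain as the feature that lowers the number, and compound 1, which also carries a hydroxyl group on the sulfur-bound chain, sits near compound 2. Removing the carbamoyl group is therefore expected to raise the number, back toward compound 1. The expected step is a 2.9-fold higher number from compound 3 to compound 4 (0.46 log units; beyond the scatter). Compound 4 is estimated at 550 nM, within 200 nM to 1500 nM.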

Compound 4, concentration for 50% growth inhibition: 636 nM
Compound 4: the middle estimate sits 1.2-fold (0.06 log units) below what was measured; measured number inside the range.
By their numbers in this assay, from the lowest: compound 3; then compounds 4, 1 and 2 (each within the scatter of the next).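

In this assay, a large carbon ring carrying a hydroxyl group on the sulfur does not match carbamoylmethyl, with a 3.3-fold higher number from compound 3 to compound 4 (0.52 log units; beyond the scatter). It also cannot be told apart from the smaller groups, with a 1.2-fold lower number from compound 2 to compound 4 (0.09 log units; within the scatter) and a 1.1-fold lower number from compound 1 to compound 4 (0.04 log units; within the scatter), so among these four compounds only carbamoylmethyl in compound 3 stands apart. No data shown here account for this.

The compounds shown leave open whether a carboxylic acid or an N-methyl amide on the same chain would keep the number of compound 3. They also leave open whether a longer chain ending in carbamoyl would do so.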